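A few compounds are considered here, and "the series" means these few. Any claim that something is new, unique, unknown or untested is made for them only; others in the source may bear on it.

Measured so far in a functional assay on MCF7 cells (Homo sapiens) for antiproliferative activity, read by sulforhodamine B assay, with a stated time of 3 days; on this read-out lower numbers stand for stronger inhibition and higher numbers for weaker inhibition:
- compound 1 `Clc1ccc(Sc2ncnc3c2ncn3C2COc3ccccc3CO2)c(Cl)c1` gives 12000 nM
- compound 2 `c1ccc2c(c1)COC(n1cnc3ncnc(OCC4CCCCC4)c31)CO2` gives 13400 nM

The number for compound 2 lies within the scatter of compound 1, so neither stands apart. Compound 3 `CSc1ncnc2ncn(C3COc4ccccc4CO3)c12` differs from compound 2 by methylsulfanyl in place of cyclohexylmethoxy on an aromatic carbon with methylsulfanyl in place of cyclohexylmethoxy on an aromatic carbon. Among the compounds with values here, no measured step covers this change, so the expectation rests on these two values alone. A modest move toward weaker inhibition in this assay is expected, with a 1.9-fold higher number from compound 2 to compound 3 (0.27 log units; within the scatter) as the estimated step. For compound 3 the estimate is 25000 nM with an expected range from 9000 nM to 70000 nM in this read-out.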

Compound 3, half-maximal inhibitory concentration: 31800 nM
Compound 3: the middle estimate sits 1.3-fold (0.10 log units) below what was measured; the range from low to high includes it.
By their numbers in this assay, from the lowest: compounds 1 and 2 (each within the scatter of the next); then compound 3.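

In this assay, within the data shown here, methylsulfanyl in place of cyclohexylmethoxy on this aromatic carbon gives a 2.4-fold higher number from compound 2 to compound 3 (0.38 log units; beyond the scatter) and so supplies the first readable step. The number at this position therefore responds to the group it carries, and the smaller group with no ring goes with weaker inhibition here. No measured evidence bears on the reason for this step. Still open, going by these compounds, is how an amine, a plain methoxy or a longer alkyl chain on this carbon would compare with cyclohexylmethoxy, and whether ring or size tracks the change.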